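One Methoxy Fewer on the Shared Core

The source may report more compounds than this note shows. Statements on the series, on what has been measured and on what is new or still open speak of the compounds shown alone.

Of the compounds shown here, two with the same overall shape have been measured in a functional assay on HeLa cells (Homo sapiens) for antiproliferative activity, read by sulforhodamine B assay, with a stated time of 48 h; on this read-out lower numbers stand for stronger inhibition and higher numbers for weaker inhibition. There, compound 1 (`COc1cc(OC)c2sc(-c3ccc(N/C=C\C(=O)c4ccc(OC)c(O)c4)cc3)nc2c1`) gives 12100 nM and compound 2 (`COc1ccc(C(=O)/C=C\Nc2ccc(-c3nc4cc(OC)c(OC)c(OC)c4s3)cc2)cc1F`) gives 7300 nM. These two values lie within the usual scatter of each other, so compound 2 stands level with compound 1 and neither can be ranked on these numbers.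

The next compound, compound 3 (`COc1cc(OC)c2sc(-c3ccc(N/C=C\C(=O)c4ccc(OC)c(F)c4)cc3)nc2c1`), is derived from compound 2 by a single change: hydrogen in place of methoxy on an aromatic carbon, (hydrogen in place of methoxy on an aromatic carbon).

For the measured compounds named here, no measured pair isolates this change, so its effect in this assay has not been seen directly. Going by the values given here, the only measured compound with hydrogen at that place is compound 1, which gives 12100 nM, although it also differs from compound 2 in a second group. On that basis, no shift beyond the scatter is expected, and no clear direction can be assigned. The expected change is a 1.3-fold higher number from compound 2 to compound 3 (0.11 log units; within the scatter). The estimated value for compound 3 is 9500 nM, with an expected range of 3500 nM to 26000 nM.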

Compound 3, half-maximal inhibitory concentration: 7300 nM
For compound 3 the middle estimate is 1.3-fold (0.11 log units) above the measured one, within the range that was stated.
By their numbers in this assay, from the lowest: compounds 2, 3 and 1 (each within the scatter of the next).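

In this assay, hydrogen in place of methoxy on the aromatic carbon ortho to two methoxy groups gives no change at the digits printed from compound 2 to compound 3 (within the scatter). For the compounds shown here, this is the first pair to isolate that swap, and it shows that, for these two compounds, the methoxy group at this place makes no difference that can be read on this assay. The second pair isolates fluoro in place of hydroxy on an aromatic carbon and gives a 1.7-fold lower number from compound 1 to compound 3 (0.22 log units; within the scatter), so those two groups cannot be ranked here either, and no measurement shown gives a reason for either result.

On these data alone, whether this place on the shared core accepts other groups just as evenly remains open, since a chloro group, an amine or a longer chain such as ethoxy there could still move the number beyond the scatter. As far as these compounds go, it is equally open whether a nitrile or a carboxylic acid at the carbon that carries fluoro in compound 3 would separate from the level these three compounds share.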